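Antiproliferative activity: a 2,6-diethylphenyl variant

A few compounds are considered here, and "the series" means these few. Any claim that something is new, unique, unknown or untested is made for them only; others in the source may bear on it.

Measured compounds:
compound 1, `CCOc1ccc(-n2nncc2CN2C(=O)C3(C(C#N)=C(N)Oc4c3c3nc5ccccc5nc3c3ccccc43)c3ccccc32)cc1`, > 50000 nM in an ADME assay on L02 cells (Homo sapiens) for antiproliferative activity, read by MTT assay, with a stated time of 48 h (on this read-out higher numbers stand for weaker inhibition and lower numbers for stronger inhibition), a limit of the assay rather than a number;
compound 2, `N#CC1=C(N)Oc2c(N)cc3nc4ccccc4nc3c2C12C(=O)N(Cc1cnnn1-c1ccccc1Br)c1ccccc12`, 29200 nM in this assay.

Among the compounds with values here, compound 2 holds the only number in this assay; the other value is a limit, at which one of the two values sits (the limit of > 50000 nM in this assay, at which 1 of the 2 values shown sits). Compound 3, `CCc1cccc(CC)c1-n1nncc1CN1C(=O)C2(C(C#N)=C(N)Oc3c(N)cc4nc5ccccc5nc4c32)c2ccccc21`, is not yet measured. It differs from compound 2 in one place: 2,6-diethylphenyl in place of 2-bromophenyl on an aromatic nitrogen. Within the data shown here, no step between two measured compounds of this set is available, so there is no precedent for what an exchange of this kind does to the read-out. The step from compound 2 to compound 3 is therefore expected to stay within the usual scatter, with a 1.0-fold higher number from compound 2 to compound 3 (0.01 log units; within the scatter) as the working assumption. On that basis compound 3 is estimated at 30000 nM in this assay, within a range from 12000 nM to 75000 nM.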

Compound 3, half-maximal inhibitory concentration: > 50000 nM
Compound 3: no number, only a limit; the forecaster's own chance of this, stated with the estimate: 30%; middle value at least 1.6-fold (0.22 log units) from the limit.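

In this assay compound 3 gives > 50000 nM, which is a limit of the assay and not a number. Placing 2,6-diethylphenyl in place of 2-bromophenyl on the aromatic nitrogen gives the first readable step at this position, an at least 1.7-fold higher number from compound 2 to compound 3 (0.23 log units; that floor lies within the scatter), so this exchange brings no lower number, while the real size of the step stays unknown. Compound 2 remains the only compound here with a number, and the limit now accounts for most of the values: the limit of > 50000 nM in this assay, at which 2 of the 3 values shown sit.

The compounds shown leave open how far the number of compound 3 lies past the limit, and so whether the step exceeds the usual scatter. They also leave open what an amine or a carboxylic acid on this phenyl ring would do to the read-out.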